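Biaryl Variation on a Spiro Piperidine Sigma Ligand

The source may hold more compounds than are shown below. What is called first, only, known or untested is meant among the compounds shown, and "the series" means these compounds.

Compound 2 `COc1ccc(-c2scc3c2CC(OC)OC32CCN(Cc3ccccc3)CC2)cc1` is one of three compounds tested in an assay on membranes from brain for displacement of a labelled ligand from Sigma non-opioid intracellular receptor 1 (Cavia porcellus), read by scintillation counting, with a stated time of 120 min (a lower number here means a stronger inhibitor, a higher number a weaker inhibitor), where compound 2 gives 2.2 nM. Compound 3 `COC1Cc2c(csc2-c2cccnc2)C2(CCN(Cc3ccccc3)CC2)O1` gives 2.2 nM, and the two are level at the digits shown, together the highest numbers of the set. Compound 1 `COC1Cc2cscc2C2(CCN(Cc3ccccc3)CC2)O1`, which carries only hydrogen at the aromatic carbon where the others bear an aryl group, gives 0.22 nM, and the change a 10-fold higher number from compound 1 to compound 2 (1.00 log units; beyond the scatter) and the change a 10-fold higher number from compound 1 to compound 3 (1.00 log units; beyond the scatter) both show that attaching an aryl group there costs potency. Between the two aryl-bearing compounds the change no change at the digits printed from compound 2 to compound 3 (within the scatter) shows no difference.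

Compound 4 `COC1Cc2c(csc2-c2ccc(-c3ccccc3)cc2)C2(CCN(Cc3ccccc3)CC2)O1` differs from compound 2 by phenyl in place of methoxy on an aromatic carbon. Among the compounds with values here, no measured step exchanges one aryl substituent for a larger one, but compound 2 and compound 3 show that two different aryl groups give the same number. The expectation is therefore a change of a 1.4-fold higher number from compound 2 to compound 4 (0.13 log units; within the scatter), within the scatter. Compound 4 is estimated at 3 nM, with a range from 1 nM to 12 nM.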

Compound 4, inhibition constant: 30 nM
Compound 4: middle estimate off by 10-fold (1.00 log units), on the low side, and the stated range ends below it.
By their numbers in this assay, from the lowest: compound 1; then compounds 2 and 3 (each within the scatter of the next); then compound 4.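

While compound 2 and compound 3 gave the same number, the aryl group on the core seemed open to exchange, but phenyl in place of methoxy gives a 14-fold higher number from compound 2 to compound 4 (1.13 log units; beyond the scatter) in this assay and is a large step. The group on the aromatic carbon para to a large group therefore matters in this assay, even though the two different aryl groups of compound 2 and compound 3 could not be told apart. No supporting information accounts for why this exchange costs so much potency.

The compounds shown leave open whether the loss follows from the added phenyl ring itself or from the departure of the methoxy group. An amine such as dimethylamino, or a longer chain such as butoxy, on that same carbon would help separate these two readings.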